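Shortening the side chain of compound 3

This account rests on a few compounds, and the source may have more. Where it says the series, first, only, none or still open, it means among the compounds named here.

Measured so far in the cytotoxicity test:
- compound 1 `C=C1C[C@H](CO)OC1=O` gives 72400 nM
- compound 2 `C=C1C[C@H]([C@H](O)c2ccccc2)OC1=O` gives 36400 nM; 40200 nM (2 entries)
- compound 3 `C=C1C[C@H]([C@@H](O)CCC)OC1=O` gives 52600 nM

In a functional assay on HL-60 cells (Homo sapiens) for cytotoxicity (a lower number here means a stronger inhibitor, a higher number a weaker inhibitor), compound 3 shows the lowest of the two single numbers, and the nearest is compound 1, whose number lies within the scatter of it; compound 2 has several entries the several entries of compound 2 in this assay, 36400 nM; 40200 nM (2 entries) and so no single number. Compound 4 `C=C1C[C@H]([C@H](C)O)OC1=O` differs from compound 3 by hydrogen in place of ethyl on a saturated chain carbon, two bonds along the chain from an oxygen on a saturated carbon and a saturated ring carbon. For the measured compounds named here, the only measured step that bears on this chain is a 1.4-fold lower number from compound 1 to compound 3 (0.14 log units; within the scatter), which runs in the opposite direction and stays within the scatter. Compound 4 is therefore expected to sit close to compound 3, with the step of a 1.1-fold higher number from compound 3 to compound 4 (0.06 log units; within the scatter) not going beyond the scatter. Compound 4 is estimated at 60000 nM, within a range from 30000 nM to 120000 nM.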

Compound 4, half-maximal inhibitory concentration: 46800 nM
Beside the measured number, compound 4's estimate is 1.3-fold (0.11 log units) above it; the range from low to high includes it.
By their numbers in this assay, from the lowest: compounds 4, 3 and 1 (each within the scatter of the next).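

In this assay propyl to methyl on this saturated chain carbon gives a 1.1-fold lower number from compound 3 to compound 4 (0.05 log units; within the scatter) and methyl in place of hydrogen gives a 1.5-fold lower number from compound 1 to compound 4 (0.19 log units; within the scatter) on the same carbon. Both steps lie within the scatter, so hydrogen, methyl and propyl at this place cannot be told apart by this read-out. No measurement shown gives a reason for this result. Going by these compounds, whether an amine, a carboxylic acid or a chain longer than propyl on this carbon would move the number beyond the scatter stays open.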